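The source may hold more compounds than are shown below. What is called first, only, known or untested is meant among the compounds shown, and "the series" means these compounds.

Measured so far:
- compound 1 `Cc1cccc(-c2cc(Cl)cc(Cl)c2/C=C/[C@@H]2C[C@@H](O)CC(=O)O2)c1`: 16 nM
- compound 2 `Cc1cc(C)c(/C=C/[C@@H]2C[C@@H](O)CC(=O)O2)c(-c2cc(C)c(F)c(C)c2)c1`: 10 nM

Both compounds were run in an assay for inhibition of 3-hydroxy-3-methylglutaryl-coenzyme A reductase (Rattus norvegicus); a higher number here means a weaker inhibitor, a lower number a stronger inhibitor. Compound 1 holds the highest of the two numbers with 16 nM, and the nearest, compound 2, gives 10 nM, a gap that lies within the scatter, so the two cannot be ordered. Compound 3 `O=C1C[C@H](O)C[C@@H](/C=C/c2c(Cl)cc(Cl)cc2CCc2ccccc2)O1` is not yet measured. It differs from compound 1 in one place: phenethyl in place of 3-methylphenyl on an aromatic carbon. Going by the values given here, no step between measured compounds covers a change of this kind, so the size of the step has no direct precedent in the set, and any expectation rests on compound 1 alone. The step of a 2.5-fold higher number from compound 1 to compound 3 (0.40 log units; beyond the scatter) is expected to run toward a higher number, somewhat beyond the scatter, though a step within the scatter cannot be excluded. Compound 3 is therefore estimated at 40 nM, with a range from 10 nM to 160 nM.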

Compound 3, half-maximal inhibitory concentration: 430 nM
Compound 3: middle estimate off by 11-fold (1.03 log units), on the low side, and the stated range ends below it.
By their numbers in this assay, from the lowest: compounds 2 and 1 (each within the scatter of the next); then compound 3.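

In this assay, the position on the aromatic carbon ortho to a large group proves sensitive to the identity of its substituent: the change from 3-methylphenyl to phenethyl gives a 27-fold higher number from compound 1 to compound 3 (1.43 log units; beyond the scatter). The swap adds little by the computed counts, as both groups carry one six-membered aromatic ring of carbon only, no hydrogen-bond donors or acceptors and no net charge, so a large step can arise here without any change in those counts. No measurement available here bears on the origin of this step.

Still open, going by these compounds, is whether the step follows from the chain that phenethyl introduces or from the loss of the ring methyl. Phenyl, benzyl and phenethyl bearing a methyl on its ring would separate these two changes on the core of compound 1.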